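This account rests on a few compounds, and the source may have more. Where it says the series, first, only, none or still open, it means among the compounds named here.

Series notes. Compound 1 `COc1ccc(F)cc1CNCCCNc1ccnc2cc(CC(C)C)ccc12`, compound 2 `COc1ccc(F)cc1CNCCCNc1ccnc2cc(Cc3ccccc3)ccc12` and compound 3 `COc1ccc(F)cc1CNCCCNc1ccnc2cc(CC3CCCCC3)ccc12` share one core and differ only in the group on a saturated chain carbon bound to an aromatic carbon. In a physicochemical assay for acid dissociation, compound 1 gives 9.47, compound 2 gives 9.47 and compound 3 gives 9.47. The steps of no change at the digits printed from compound 1 to compound 2 (within the scatter), no change at the digits printed from compound 1 to compound 3 (within the scatter) and no change at the digits printed from compound 2 to compound 3 (within the scatter) all stay within the scatter, so compound 3 stands level with compound 1 and compound 2 in this assay.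

Compound 4 `COc1ccc(F)cc1CNCCCNc1ccnc2cc(Oc3ccc(Cl)cc3)ccc12` is not yet measured. Relative to compound 3 the change is 4-chlorophenoxy in place of cyclohexylmethyl on an aromatic carbon. For the measured compounds named here, none of the measured steps sits on an aromatic carbon of the core; all three were exchanges of isopropyl, phenyl and cyclohexyl on a saturated chain carbon, and none of them moved this assay beyond the scatter. Going by the values given here, the bearing of those steps on the new change is thus indirect, and the series holds no step of the kind now taken. On that basis the expectation is that this assay for compound 4 changes little, with a number 0.07 log units lower from compound 3 to compound 4 (within the scatter) expected to fall within the scatter. Compound 4 is estimated at 9.4, with a range from 9 to 9.8.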

Compound 4, acid dissociation constant: 9.28
Estimate against measurement, compound 4: 0.12 log units above, and the stated range covers the measured number.
By their numbers in this assay, from the lowest: compounds 4, 1, 2 and 3 (each within the scatter of the next).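

In this assay the exchange on the aromatic carbon, meta to a fused ring and para to a fused ring, reads a number 0.19 log units lower from compound 3 to compound 4 (within the scatter) against cyclohexylmethyl, a number 0.19 log units lower from compound 2 to compound 4 (within the scatter) against benzyl and a number 0.19 log units lower from compound 1 to compound 4 (within the scatter) against isobutyl. The read-out thus stays within the scatter with 4-chlorophenoxy at this position, a group bringing an oxygen and a chlorine that none of the exchanges on the saturated chain carbon included. No supporting data bear on what sets the value at this position.

Going by these compounds, whether an amine or a carboxylic acid on this aromatic carbon would also stay within the scatter remains open. Also open, on these data alone, is what phenoxy without the chlorine would give, so the oxygen and the chlorine cannot be read apart.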